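This account rests on a few compounds, and the source may have more. Where it says the series, first, only, none or still open, it means among the compounds named here.

Within the data shown here, compound 1 `Cc1cc(-c2ccc(F)cc2)nn1Cc1ccc(C(=O)NO)cc1` gives 8 nM in an assay on cells for inhibition of protein deacetylase HDAC6 (Homo sapiens), read by fluorescence, with stated times of 15 min and 60 min (on this read-out higher numbers stand for weaker inhibition and lower numbers for stronger inhibition), the lowest of the two numbers measured so far; compound 2 `CCCc1cc(-c2ccc(F)cc2)nn1Cc1ccc(C(=O)NO)cc1` gives 107 nM. Among the measured compounds shown here, the step of a 13-fold higher number from compound 1 to compound 2 (1.13 log units; beyond the scatter) came with ethyl in place of hydrogen on a saturated chain carbon bound to an aromatic carbon, and it is the only measured step. Compound 3 `Cc1ccc(-c2cc(C)n(Cc3ccc(C(=O)NO)cc3)n2)cc1` differs from compound 1 by methyl in place of fluoro on an aromatic carbon: fluoro leaves and methyl enters on an aromatic carbon of the six-membered ring of carbon only, para to a large group; cut one bond further out, 4-fluorophenyl becomes 4-methylphenyl. For the measured compounds named here, no measured step touches that ring, and the step from compound 1 to compound 2 concerns the chain on the shared core, so it does not bear directly on this change. The expectation is therefore a step of a 1.3-fold higher number from compound 1 to compound 3 (0.10 log units; within the scatter), not beyond the scatter in either direction. Compound 3 is estimated at 10 nM, with a range from 4 nM to 30 nM.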

Compound 3, half-maximal inhibitory concentration: 7 nM
For compound 3 the middle estimate is 1.4-fold (0.15 log units) above the measured one, within the range that was stated.
By their numbers in this assay, from the lowest: compounds 3 and 1 (each within the scatter of the next); then compound 2.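

In this assay, among these compounds, the change from 4-fluorophenyl to 4-methylphenyl gives a 1.1-fold lower number from compound 1 to compound 3 (0.06 log units; within the scatter), the first measured exchange on this aromatic carbon para to a large group. Within this one pair, methyl and fluoro are not separated by the read-out, whereas the change on the chain of the shared core gave a 13-fold higher number from compound 1 to compound 2 (1.13 log units; beyond the scatter). No available evidence accounts for compound 1 and compound 3 reading alike.

Going by these compounds, whether this carbon accepts groups that differ more from fluoro and methyl, such as an amine, a carboxylic acid or a longer chain, remains open. Also open, on these data alone, is whether the exchange of fluoro for methyl would read the same with the longer chain of compound 2 on the shared core.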